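The source may report more compounds than this note shows. Statements on the series, on what has been measured and on what is new or still open speak of the compounds shown alone.

Compound 1, `CN(Cc1ccccc1)Cc1ccc[nH]1`: 20 nM
Compound 2, `CN(CCCc1ccccc1)C(=O)c1ccc[nH]1`: 8900 nM
Compound 3, `O=C(NCCCCc1ccccc1)c1ccc[nH]1`: 57000 nM

In an assay on mitochondria for inhibition of Amine oxidase [flavin-containing] B (Bos taurus), read by fluorescence (on this read-out higher numbers stand for weaker inhibition and lower numbers for stronger inhibition), compound 3 gives the highest of the three numbers, with compound 2 nearer to it and compound 1 far below. Compound 4, `CN(CCCCc1ccccc1)C(=O)c1ccc[nH]1`, differs from compound 3 by methyl in place of hydrogen on an amide-type nitrogen. Among the compounds with values here, no measured pair shows this change on its own, so its size cannot be read off directly; compound 2, which also carries a methyl on its amide-type nitrogen though it differs elsewhere as well, gives 8900 nM, while compound 3 gives 57000 nM. On that showing the change is expected to lower the number in this assay, by about a 5.7-fold lower number from compound 3 to compound 4 (0.76 log units; beyond the scatter). Compound 4 is therefore estimated at 10000 nM, within a range from 3000 nM to 40000 nM.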

Compound 4, inhibition constant: 2500 nM
Estimate against measurement, compound 4: 4.0-fold (0.60 log units) above, and the stated range ends above it.
By their numbers in this assay, from the lowest: compound 1; then compound 4; then compound 2; then compound 3.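

Read directly for the first time, methyl in place of hydrogen on the amide-type nitrogen gives in this assay a 23-fold lower number from compound 3 to compound 4 (1.36 log units; beyond the scatter) and is large and beyond the scatter. Within the data shown here, the earlier compounds held no pair that differed only at this position, so this is the first measure of the change on its own. Nothing available explains why the step is this large. From the compounds shown here alone, whether an ethyl group or a longer chain on this nitrogen would lower the number further remains open. So does whether methyl gives a step of this size in compounds with a different chain.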